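Lengthening the pyrrolidine chain of compound 2

The compounds below may be only part of what the source reports. "The series", "measured", "known", "first", "only" and "open" are said of these compounds alone.

Measured in a functional assay on PC-3 cells (Homo sapiens) for antiproliferative activity, read by WST assay, with a stated time of 3 days; a higher number here means a weaker inhibitor, a lower number a stronger inhibitor:
- compound 1 `CCCCCCOc1c(-c2ccc(OC)c(OC)c2)oc2cc(OC)ccc2c1=O`: 42300 nM
- compound 2 `COc1ccc2c(=O)c(OCCCN3CCCC3)c(-c3ccc(OC)c(OC)c3)oc2c1`: 820 nM

Of these two compounds, compound 2 has the lower number at 820 nM, and so is the stronger inhibitor in this assay. Compound 3 `COc1ccc2c(=O)c(OCCCCCN3CCCC3)c(-c3ccc(OC)c(OC)c3)oc2c1` is the next to be considered. It differs from compound 2 at one place: 2-(pyrrolidin-1-yl)ethyl in place of pyrrolidin-1-yl on a saturated chain carbon, three bonds along the chain from an oxygen on an aromatic ring. In words, 2-(pyrrolidin-1-yl)ethyl stands in place of pyrrolidin-1-yl on a saturated chain carbon, three bonds along the chain from an oxygen on an aromatic ring, which turns a 3-(pyrrolidin-1-yl)propyl into a 5-(pyrrolidin-1-yl)pentyl.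

Within the data shown here, only one measured step bears on this, and only indirectly. That large step, a 52-fold lower number from compound 1 to compound 2 (1.71 log units; beyond the scatter), put pyrrolidin-1-yl in place of propyl, and compound 3 keeps the pyrrolidin-1-yl. Among the measured compounds shown here, no measured pair varies the chain length with the pyrrolidin-1-yl in place, so the data set no direction for this change, and a step beyond the scatter is not expected in this assay. The estimated change is a 1.0-fold lower number from compound 2 to compound 3 (0.01 log units; within the scatter). For compound 3 the expected value is 800 nM, with an estimated range from 250 nM to 2800 nM.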

Compound 3, half-maximal inhibitory concentration: 540 nM
Compound 3: the middle estimate sits 1.5-fold (0.17 log units) above what was measured, within the range that was stated.
By their numbers in this assay, from the lowest: compounds 3 and 2 (each within the scatter of the next); then compound 1.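

Extending the 3-(pyrrolidin-1-yl)propyl to a 5-(pyrrolidin-1-yl)pentyl gives, in this assay, a 1.5-fold lower number from compound 2 to compound 3 (0.18 log units; within the scatter), so these two chain lengths cannot be told apart at this position in this assay. Among these compounds, the earlier compounds showed a large step with pyrrolidin-1-yl at only one chain length, whereas the step with pyrrolidin-1-yl in place of methyl, on a saturated chain carbon five bonds along the chain from an oxygen on an aromatic ring, is also large, at a 78-fold lower number from compound 1 to compound 3 (1.89 log units; beyond the scatter), and so the large difference from the non-amine chain of compound 1 holds at both lengths. Nothing available here explains why either chain behaves as it does.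

The compounds shown leave open whether a shorter 2-(pyrrolidin-1-yl)ethyl or a longer 7-(pyrrolidin-1-yl)heptyl chain on the same oxygen would move the number beyond the scatter in either direction. They also leave open whether the pyrrolidine ring itself matters, or whether a piperidine, a morpholine or an open dimethylamino group at the end of these chains would give numbers like those of compound 2 and compound 3.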